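A few compounds are considered here, and "the series" means these few. Any claim that something is new, unique, unknown or untested is made for them only; others in the source may bear on it.

Compound 1, `C=CC[C@@H]1C[C@@H](c2ccc(Cl)c(Cl)c2)[C@H](NC(=O)c2cc(-c3c(Cl)cnn3C)c(Cl)o2)CN1`, gives 12.4 nM in an assay for inhibition of RAC-alpha serine/threonine-protein kinase (Homo sapiens), read by HTRF, with a stated time of 1 h; a higher number here means a weaker inhibitor, a lower number a stronger inhibitor.
Compound 2, `Cn1ncc(Cl)c1-c1cc(C(=O)N[C@@H]2CN[C@H](CC(O)CO)C[C@H]2c2ccc(F)c(F)c2)oc1Cl`, gives 3.31 nM in this assay.
Compound 3, `Cn1ncc(Cl)c1-c1cc(C(=O)N[C@@H]2CN[C@H](CCNS(C)(=O)=O)C[C@H]2c2ccc(F)c(F)c2)oc1Cl`, gives 3.29 nM in this assay.

Among these three numbers compound 1 stands highest, so it is the weakest inhibitor shown; compound 2 and compound 3 both lie well below it, beyond the scatter, while the two of them sit within the scatter of each other.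

Compound 4, `Cn1ncc(Cl)c1-c1cc(C(=O)N[C@@H]2CN[C@H](CCN3CCCCC3)C[C@H]2c2ccc(Cl)c(Cl)c2)oc1Cl`, has not yet been measured in this assay. Against compound 1 it carries one change at the side chain attached to the saturated ring carbon: (piperidin-1-yl)methyl in place of vinyl on a saturated chain carbon bound to a saturated ring carbon.

Within the data shown here, only one measured step speaks to that part of the molecule. Between compound 2 and compound 3 the side chain on the same kind of position was exchanged, and the result was a 1.0-fold lower number from compound 2 to compound 3 (0.00 log units; within the scatter). That single step suggests the side chain can be varied there without a large shift, though it concerns different groups than the ones exchanged here, and compound 2 and compound 3 also carry a differently substituted phenyl ring than compound 1. The shift expected for compound 4 is therefore small, a 1.6-fold lower number from compound 1 to compound 4 (0.19 log units; within the scatter), and may well stay within the scatter. Compound 4 is estimated at 8 nM, within a range from 3 nM to 22 nM.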

Compound 4, half-maximal inhibitory concentration: 5.65 nM
For compound 4 the middle estimate is 1.4-fold (0.15 log units) above the measured one; the range from low to high includes it.
By their numbers in this assay, from the lowest: compounds 3, 2 and 4 (each within the scatter of the next); then compound 1.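

Replacing vinyl with (piperidin-1-yl)methyl on a saturated chain carbon bound to a saturated ring carbon gives a 2.2-fold lower number from compound 1 to compound 4 (0.34 log units; beyond the scatter) in this assay, so this position accepts a group of 7 heavy atoms, including a six-membered non-aromatic ring, in place of one of 2 heavy atoms, with a modest gain rather than a loss. Among these compounds, the only earlier step at this position, a 1.0-fold lower number from compound 2 to compound 3 (0.00 log units; within the scatter), showed no measurable change, whereas this one shows that exchanging the side chain can move the number beyond the scatter, and it does so with the rest of compound 1 left unchanged. Nothing in the data shown accounts for this shift.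

Among the compounds shown here, with only this one exchange, the gain cannot be assigned to the ring nitrogen, the ring or simply the longer side chain; a cyclohexylmethyl group, a dimethylaminomethyl group or a morpholin-4-ylmethyl group at the same place would help separate these parts. Going by these compounds, it also remains open whether the same exchange would give a similar shift with the differently substituted phenyl ring of compound 2 and compound 3.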